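Sulfanyl for chloro on the shared core

This account rests on a few compounds, and the source may have more. Where it says the series, first, only, none or still open, it means among the compounds named here.

Measured compounds:
compound 1 `c1ccc(CNc2[nH]ccc3ncnc2-3)cc1` — 9 mg/kg
compound 2 `CCCCCCNc1[nH]ccc2ncnc1-2` — > 9 mg/kg
compound 3 `Clc1[nH]ccc2ncnc1-2` — > 9 mg/kg

The read-out throughout is a functional assay on the whole organism (Pleural cavity) with Rattus norvegicus as the target; a lower number here means that less compound is needed, a higher number that more compound is needed for the effect. Compound 1 gives a number in this assay, 9 mg/kg. For compound 2 the assay reports only a limit, > 9 mg/kg. For compound 3 the assay likewise reports only a limit, > 9 mg/kg. This is the limit of > 9 mg/kg in this assay, at which 2 of the 3 values shown sit, so compound 3 stands not at a number but at the limit, and only compound 1 carries a measured value. For the measured compounds named here, no step between two measured compounds is known in this assay, and nothing about the size of a change on the shared core has been measured.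

Compound 4 `Sc1[nH]ccc2ncnc1-2` differs from compound 3 by sulfanyl in place of chloro on an aromatic carbon. Going by the values given here, with no measured step to rest on, the step from compound 3 to compound 4 is expected to be small, none beyond the scatter: a step that the limit leaves unreadable from compound 3 to compound 4. Compound 4 is accordingly estimated at 12 mg/kg, in the range 5 mg/kg to 30 mg/kg, and a report of only a limit rather than a number remains likely for compound 4.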

Compound 4, dose for half-maximal effect: 8 mg/kg
Compound 4: middle estimate off by 1.5-fold (0.18 log units), on the high side; low and high end bracket the measured number.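

In this assay, sulfanyl in place of chloro on this aromatic carbon next to the ring nitrogen gives an at least 1.1-fold lower number from compound 3 to compound 4 (0.05 log units; that floor lies within the scatter). Compound 3 still stands at a limit and not at a number, as the printed sign shows: the limit of > 9 mg/kg in this assay, at which 2 of the 4 values shown sit. The change thus gives the shared core a second readable value, with compound 1 at 9 mg/kg and compound 4 at 8 mg/kg, and the sulfanyl compound carries no chain or added ring at this place.

As far as these compounds go, the true size of the step stays unknown, since only its floor can be read, and that floor does not show whether the exchange matters at all. From the compounds shown here alone, whether a hydroxyl or a methylsulfanyl group at this place would also give a number remains open.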